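A few compounds are considered here, and "the series" means these few. Any claim that something is new, unique, unknown or untested is made for them only; others in the source may bear on it.

Working notes on the series. In a functional assay on MCF7 cells (Homo sapiens) for inhibition (a higher number here means a weaker inhibitor, a lower number a stronger inhibitor), compound 1 (`CCCCCCCC[C@@]1(C)SC(O)=C(C)C1=O`) gives 16.5 ug/mL and compound 2 (`CCCCCC[C@@]1(C)SC(=O)C=C1OCCCCCl`) gives 8.6 ug/mL as its reading, so these two values lie within the usual scatter of each other. Compound 3 (`C=CCC1(C)C(=O)S[C@](C)(CCCCCCCC)C1=O`) has no number, only a limit of the assay (> 50 ug/mL). Compound 2 therefore stands level with compound 1 among the two numerical readings.

The next entry is compound 4 (`CCCCCC[C@@]1(C)SC(=O)C=C1OCC(=O)NCC(=O)O`), which carries (carboxymethyl)carbamoyl in place of 3-chloropropyl on a saturated chain carbon bound to an oxygen on an unsaturated carbon. Among the measured compounds shown here, no measured pair isolates this change, so the expectation is a judgement and remains loose. Starting from compound 2 at 8.6 ug/mL as its reading, a moderate step towards weaker inhibition is expected, beyond the scatter. The estimated change is a 3.5-fold higher number from compound 2 to compound 4 (0.54 log units; beyond the scatter) in this assay as the working figure. For compound 4 the expected value is 30 ug/mL with an estimated range of 12 ug/mL to 50 ug/mL in this assay.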

Compound 4, half-maximal inhibitory concentration: 6.6 ug/mL
Estimate against measurement, compound 4: 4.5-fold (0.66 log units) above, outside the stated range (below it).
By their numbers in this assay, from the lowest: compounds 4, 2 and 1 (each within the scatter of the next, the first and the last beyond it). At a limit, above all of these: compound 3.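

In this assay, (carboxymethyl)carbamoyl in place of 3-chloropropyl on a saturated chain carbon bound to an oxygen on an unsaturated carbon gives a 1.3-fold lower number from compound 2 to compound 4 (0.11 log units; within the scatter) and thus no separable difference between the two compounds. Among the compounds shown here, this is the first pair that differs in one place, and it shows that a group of 7 heavy atoms with nitrogen and oxygen and a group of 4 heavy atoms with chlorine read alike at this position in this assay. The data shown offer no measurement that bears on why these two readings match.

A methyl ester or a primary amine in place of the carboxymethyl end would test whether the carboxylic acid matters on its own. On these data alone, whether the same match holds with a longer chain on the shared core stays open.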